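This account rests on a few compounds, and the source may have more. Where it says the series, first, only, none or still open, it means among the compounds named here.

Working notes on the ester series. Among the compounds with values here, in a functional assay on DU-145 cells (Homo sapiens) for cytotoxicity, read by MTT assay (a lower number here means a stronger inhibitor, a higher number a weaker inhibitor), compound 1 `CCC(C)(O)CC(=O)O[C@H](CC=C(C)C)C1=CC(=O)c2c(O)ccc(O)c2C1=O` gives 16000 nM, the lowest of the three numbers so far. Compound 2 `CC(C)=CC[C@@H](OC[C@H](C)O)C1=CC(=O)c2c(O)ccc(O)c2C1=O` gives 24500 nM in this assay, and compound 3 `CC(C)=CC[C@@H](OC(=O)C1CCOC1)C1=CC(=O)c2c(O)ccc(O)c2C1=O` gives 47500 nM. The step of a 1.5-fold higher number from compound 1 to compound 2 (0.19 log units; within the scatter) swaps the whole ester for an ether and stays within the scatter; the step of a 3.0-fold higher number from compound 1 to compound 3 (0.47 log units; beyond the scatter), a replacement of the hydroxyalkyl chain on the carbonyl carbon by a ring, is the only one beyond the scatter, and it is modest; the step of a 1.9-fold higher number from compound 2 to compound 3 (0.29 log units; within the scatter) is within the scatter.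

Compound 4 `CCCC(O)CC(=O)O[C@H](CC=C(C)C)C1=CC(=O)c2c(O)ccc(O)c2C1=O` differs from compound 1 only within the side chain of the ester: 1-hydroxybutyl in place of 1-hydroxy-1-methylpropyl on a saturated chain carbon bound to a carbonyl carbon. Within the data shown here, no measured pair isolates a change this small; the nearest guide is the step of a 3.0-fold higher number from compound 1 to compound 3 (0.47 log units; beyond the scatter), where a larger change at the same carbonyl carbon gave only a modest movement. A step from compound 1 to compound 4 within the scatter is therefore expected, a 1.1-fold higher number from compound 1 to compound 4 (0.05 log units; within the scatter). For compound 4 the expected value in this assay is 18000 nM, with a range from 8000 nM to 40000 nM.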

Compound 4, half-maximal inhibitory concentration: > 100000 nM
Compound 4 ended at the assay's limit (the forecaster's own chance of this, stated with the estimate: 5%); middle value at least 5.5-fold (0.74 log units) from the limit.
By their numbers in this assay, from the lowest: compounds 1, 2 and 3 (each within the scatter of the next, the first and the last beyond it). At a limit, above all of these: compound 4.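

A single rearrangement within the same atoms at this position, on a saturated chain carbon bound to a carbonyl carbon, moves the number further than the earlier changes suggested: 1-hydroxybutyl in place of 1-hydroxy-1-methylpropyl gives an at least 6.2-fold higher number from compound 1 to compound 4 (0.79 log units; beyond the scatter). Compound 4 also separates from the ring ester and from the ether, with an at least 2.1-fold higher number from compound 3 to compound 4 (0.32 log units; beyond the scatter) and an at least 4.0-fold higher number from compound 2 to compound 4 (0.61 log units; beyond the scatter), so the side chain of the ester matters in this assay in a way that compounds 1, 2 and 3 did not reveal. The value of compound 4 is a limit of the assay and not a number, so the true size of these steps stays unknown: the limit of > 100000 nM in this assay, at which 1 of the 4 values shown sits.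

The compounds shown do not tell whether the unbranched chain alone accounts for the step. From the compounds shown here alone, whether a shorter chain such as 1-hydroxyethyl, or an amine in place of the hydroxyl on this chain, would stay near compound 1 remains open.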